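This account rests on a few compounds, and the source may have more. Where it says the series, first, only, none or still open, it means among the compounds named here.

Measured in a functional assay on HepG2 cells (Homo sapiens) for cytotoxicity, read by MTT assay, with a stated time of 48 h; on this read-out higher numbers stand for weaker inhibition and lower numbers for stronger inhibition:
- Compound 1 `CC1=NN(C(=O)CCl)C(c2cc(Br)ccc2O)C1`: 16300 nM
- Compound 2 `CC1=NN(S(=O)(=O)c2ccc(C)cc2)C(c2cc(Br)ccc2O)C1`: 20800 nM
- Compound 3 `O=C(c1ccccc1Cl)N1N=C(c2cc3ccccc3oc2=O)CC1c1ccccc1`: 5440 nM

Compound 3 has the lowest of the three numbers, and the other two lie beyond the scatter from it. Compound 4 `CC(C)(C)NCC(=O)N1N=C(c2cc3ccccc3oc2=O)CC1c1ccccc1` departs from compound 3 in one place, with ((tert-butyl)amino)methyl in place of 2-chlorophenyl on a carbonyl carbon. For the measured compounds named here, no measured pair isolates this change, so the only guide is the overall spread, from compound 3 at 5440 nM to compound 2 at 20800 nM. A modest move towards a higher number is expected in this assay, probably within the scatter, with an estimated 1.5-fold higher number from compound 3 to compound 4 (0.17 log units; within the scatter). For compound 4 the estimated value is 8000 nM, with an expected range of 2500 nM to 25000 nM.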

Compound 4, half-maximal inhibitory concentration: 31400 nM
Beside the measured number, compound 4's estimate is 3.9-fold (0.59 log units) below it, outside the stated range (above it).
By their numbers in this assay, from the lowest: compound 3; then compounds 1, 2 and 4 (each within the scatter of the next).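

On the carbonyl carbon, ((tert-butyl)amino)methyl in place of 2-chlorophenyl gives a 5.8-fold higher number from compound 3 to compound 4 (0.76 log units; beyond the scatter) in this assay and so shows that the group held at this position can move the number beyond the scatter. The change removes the aromatic ring and adds a hydrogen-bond donor and acceptor, but nothing available ties the step to either of these. Going by these compounds, whether losing the 2-chlorophenyl or gaining the amine matters more stays open. A plain phenyl or a morpholinomethyl group on this carbonyl carbon could help separate the two.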